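The source may hold more compounds than are shown below. What is called first, only, known or untested is meant among the compounds shown, and "the series" means these compounds.

In a functional assay on P388 cells (Mus musculus) for cytotoxicity (on this read-out lower numbers stand for stronger inhibition and higher numbers for weaker inhibition), compound 2 (`Cc1cc(-c2c(F)cc3c(=O)c(Cc4c[nH]cn4)cn(C4CC4)c3c2F)cc(C)n1`) gives 390 nM as the lower of two numbers, while compound 1 (`Cc1cc(-c2c(F)cc3c(=O)c(Cc4ccc(O)cc4)cn(C4CC4)c3c2F)cc(C)n1`) gives 1500 nM and stands higher. Within the data shown here, only one measured step bears on what follows, a 3.8-fold lower number from compound 1 to compound 2 (0.59 log units; beyond the scatter) at the same place on the chain. Compound 3 (`Cc1cc(-c2c(F)cc3c(=O)c(Cc4cc(O)ccc4O)cn(C4CC4)c3c2F)cc(C)n1`) brings a further change (2,5-dihydroxyphenyl in place of 1H-imidazol-4-yl on a saturated chain carbon bound to an aromatic carbon), with 2,5-dihydroxyphenyl in place of 1H-imidazol-4-yl on a saturated chain carbon bound to an aromatic carbon. Its entering ring is of carbon only, as in compound 1 at 1500 nM so a modest move back toward higher numbers is expected. An estimated 2.1-fold higher number from compound 2 to compound 3 (0.31 log units; beyond the scatter) is expected. Compound 3 is estimated at 800 nM with a range of 200 nM to 3000 nM as the expected span.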

Compound 3, half-maximal inhibitory concentration: 360 nM
The estimate for compound 3 lay 2.2-fold (0.35 log units) above the measured number, and the stated range covers the measured number.
By their numbers in this assay, from the lowest: compounds 3 and 2 (each within the scatter of the next); then compound 1.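

In this assay, a 1.1-fold lower number from compound 2 to compound 3 (0.03 log units; within the scatter) shows that a ring of carbon only can stand on this saturated chain carbon and match the 1H-imidazol-4-yl compound, so ring nitrogen is not required here. Within carbon-only rings, a 4.2-fold lower number from compound 1 to compound 3 (0.62 log units; beyond the scatter) ties the earlier gap to the ring's hydroxyl pattern rather than to the loss of nitrogen. No measurement is available to explain either step. Still open, as far as these compounds go, is how an amine or a carboxylic acid in place of the hydroxyl groups, or a longer chain to the ring, would read out here.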